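The compounds below may be only part of what the source reports. "The series", "measured", "known", "first", "only" and "open" are said of these compounds alone.

Measured so far in a functional assay on the whole organism (strain Wistar) for inhibition, with Rattus norvegicus as the target, read by paw edema, with stated times of 60 min and 1 h, at a dose of 100 mg/kg by the oral route; on this read-out lower numbers stand for less inhibition and higher numbers for more inhibition at the one dose given (going by the name of the read-out): compound 1 `COc1cc2c(cc1OC)C(CC(N)=O)CC2` gives 18.8%; compound 2 `CCCCCCNC(=O)CC1CCc2cc(OC)c(OC)cc21` gives 47.6%.

Within the data shown here, compound 2 stands highest of the two, with compound 1 the only neighbour, the step being a number 28.8 percentage points higher from compound 1 to compound 2 (beyond the scatter). Compound 3 `COc1cc2c(cc1OC)C(CC(=O)N1CCCC1)CC2` is not yet measured; it differs from compound 2 by pyrrolidin-1-yl in place of hexylamino on a carbonyl carbon. Among the measured compounds shown here, no measured step changes the group on the carbonyl carbon in this way; the only step known, a number 28.8 percentage points higher from compound 1 to compound 2 (beyond the scatter), concerns hexyl in place of hydrogen on an amide-type nitrogen and bears on it only indirectly. A step of moderate size downward, or none beyond the scatter, is expected, a number 12.6 percentage points lower from compound 2 to compound 3 (beyond the scatter). The estimate for compound 3 in this assay is 35%, within 15% to 55%.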

Compound 3, a percentage reported as inhibition, in the whole organism at one dose (the size of the read-out at that dose, not a potency): 4.69%
Compound 3: the middle estimate sits 30.3 percentage points above what was measured, and the stated range ends above it.
By their numbers in this assay, from the lowest: compound 3; then compound 1; then compound 2.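

In this assay, pyrrolidin-1-yl on the carbonyl carbon gives a number 42.9 percentage points lower from compound 2 to compound 3 (beyond the scatter) and also a number 14.1 percentage points lower from compound 1 to compound 3 (beyond the scatter), so this group falls short of both hexylamino and amino. Replacing the amide hydrogen therefore does not raise the number in itself: compound 2 follows that direction, while compound 3 goes against it. No measurement available explains this difference. Still open, on these data alone, is how a butylamino chain or a piperidin-1-yl ring on the carbonyl carbon would read, and whether a carboxylic acid there would retain any inhibition.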